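This account rests on a few compounds, and the source may have more. Where it says the series, first, only, none or still open, it means among the compounds named here.

Compound 1, `COc1ccc(/C=C/S(=O)(=O)Cc2ccc(OC)c(N)c2)cc1`, and compound 3, `COc1ccc(/C=C/S(=O)(=O)Cc2ccc(OC)c(N)c2)c(OC)c1`, share a core and differ by one change: methoxy in place of hydrogen on an aromatic carbon. In a functional assay on K562 cells (Homo sapiens) for cytotoxicity, read by trypan blue exclusion, with a stated time of 96 h (on this read-out higher numbers stand for weaker inhibition and lower numbers for stronger inhibition), compound 1 gives 2500 nM. In this assay compound 3 gives 500 nM, so the added methoxy brought a 5.0-fold lower number from compound 1 to compound 3 (0.70 log units; beyond the scatter).

Compound 2, `COc1ccc(CS(=O)(=O)/C=C/c2c(OC)cccc2OC)cc1[N+](=O)[O-]`, is built on a different core; how its core differs from that of compound 1 is not broken down here. In this assay compound 2 gives 20000 nM, the highest of the three numbers.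

Compound 4, `COc1cc(OC)c(/C=C/S(=O)(=O)Cc2ccc(OC)c([N+](=O)[O-])c2)c(OC)c1`, is not yet measured. It differs from compound 2 by methoxy in place of hydrogen on an aromatic carbon. Going by the values given here, this is the same kind of change as the one from compound 1 to compound 3, but the surroundings are not the same: in compound 3 the new methoxy sits ortho to a large group and meta to a methoxy group, whereas in compound 4 it sits meta to two methoxy groups and para to a large group, on a different core.

Resting only on the single measured example, where the step from compound 1 to compound 3 was a 5.0-fold lower number from compound 1 to compound 3 (0.70 log units; beyond the scatter), a smaller gain is expected for compound 4: the place and the core differ, and nothing here shows how the change behaves on the core of compound 2. The step from compound 2 to compound 4 is estimated at a 2.5-fold lower number from compound 2 to compound 4 (0.40 log units; beyond the scatter). For compound 4 in this assay the estimate is 8000 nM, expected to fall between 2500 nM and 25000 nM.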

Compound 4, half-maximal inhibitory concentration: 2500 nM
For compound 4 the middle estimate is 3.2-fold (0.51 log units) above the measured one, within the range that was stated.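

In this assay the added methoxy brought an 8.0-fold lower number from compound 2 to compound 4 (0.90 log units; beyond the scatter) and so lowered the number on the core of compound 2, as it had on the core of compound 1. The two steps cannot be told apart in size, so in this small set the change carried over from one core to the other with its effect intact: the same change on two cores in this assay, a 5.0-fold lower number (0.70 log units; beyond the scatter) from compound 1 to compound 3 and an 8.0-fold lower number (0.90 log units; beyond the scatter) from compound 2 to compound 4, 1.6-fold (0.20 log units) apart, within the scatter of two such steps. This is not a general rule, however, since it rests on just two pairs of compounds, the new methoxy does not sit in the same surroundings in both pairs, and the numbers alone do not explain why the added group lowers the read-out.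

The compounds shown leave open whether another group on the same aromatic carbon, such as an ethoxy, a hydroxyl or a fluorine atom, would bring a step of similar size, or whether the effect is particular to methoxy. They also leave open whether the same step would appear on any core beyond these two, and whether it would survive a move of the methoxy to another carbon of the ring.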